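This account rests on a few compounds, and the source may have more. Where it says the series, first, only, none or still open, it means among the compounds named here.

Measured so far: compound 1 `Fc1ccc(NCc2ccc(CNc3ccc(F)cn3)cc2)nc1` with 45%, and compound 2 `Fc1ccc(NCc2ccc(CNc3ncccn3)cc2)nc1` with 90%.

In a functional assay on MDA-MB-231 cells for antagonist activity at C-X-C chemokine receptor type 4 (Homo sapiens), tested at 10 nM (a lower number here means a weaker effect, a higher number a stronger effect of the compound at the concentration tested), compound 2 gives the higher of the two numbers, lying a number 45 percentage points higher from compound 1 to compound 2 (beyond the scatter). Compound 3 `Clc1cccc(NCc2ccc(CNc3ncccn3)cc2)n1` differs from compound 2 by 6-chloropyridin-2-yl in place of 5-fluoropyridin-2-yl on an amine nitrogen. For the measured compounds named here, the only measured step, the change from compound 1 to compound 2, concerns a different replacement and is large, so it gives no direct guide. Because compound 2 already shows 90%, little room remains upward; the step of a number 8 percentage points lower from compound 2 to compound 3 (within the scatter) is expected to stay within the scatter. Compound 3 is estimated at 82%, between 55% and 96%.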

Compound 3, a percentage reported as inhibition, at one concentration (the size of the read-out at that concentration, not a potency): 100%
Estimate against measurement, compound 3: 18 percentage points below; the whole stated range lies below it.
By their numbers in this assay, from the lowest: compound 1; then compounds 2 and 3 (each within the scatter of the next).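

In this assay, the step of a number 10 percentage points higher from compound 2 to compound 3 (within the scatter) shows that, with pyrimidin-2-yl held constant, this amine nitrogen accepts 6-chloropyridin-2-yl in place of 5-fluoropyridin-2-yl without a change beyond the scatter. For the compounds shown here, the earlier step concerned only pyrimidin-2-yl in place of 5-fluoropyridin-2-yl, so this is the first reading of a swap between two halogenated pyridines here. Nothing given here bears on why these two groups read alike.

From the compounds shown here alone, whether a phenyl or a 6-methylpyridin-2-yl group would hold up at this nitrogen remains open. Also open, going by these compounds, is how compound 2 and compound 3 would compare at a lower concentration.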